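Swapping fluoro for chloro in compound 1

The source may report more compounds than this note shows. Statements on the series, on what has been measured and on what is new or still open speak of the compounds shown alone.

In a functional assay (aorta) with Rattus norvegicus as the target (a higher number here means that more compound is needed for the effect, a lower number that less compound is needed), compound 1 `CCNC1=NS(=O)(=O)c2cc(F)ccc2N1` gives > 300 uM, which is a limit of the assay and not a number. Compound 2 `CC(C)C(C)NC1=NS(=O)(=O)c2cc(F)ccc2N1` gives 26.4 uM. Going by the values given here, the only measured step, an at least 11-fold lower number from compound 1 to compound 2 (1.05 log units; beyond the scatter), is large and beyond the scatter, but it alters the saturated chain and not the aromatic carbon. Compound 3 `CCNC1=NS(=O)(=O)c2cc(Cl)ccc2N1` carries chloro in place of fluoro on an aromatic carbon. Among the compounds with values here, no measured step tests this swap, so only a modest move toward a lower number is expected. The expected change is an at least 2.0-fold lower number from compound 1 to compound 3 (0.30 log units; that floor lies within the scatter). Compound 3 is expected near 150 uM, with an estimated range of 40 uM to 500 uM.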

Compound 3, concentration for half-maximal effect: 39.9 uM
Compound 3: middle estimate off by 3.8-fold (0.58 log units), on the high side; the measured number lies below the stated range.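

Going by these compounds alone, this is the first step at the aromatic carbon, and swapping fluoro for chloro there gives an at least 7.5-fold lower number from compound 1 to compound 3 (0.87 log units; beyond the scatter), so in this assay the halogen at this position matters, not only the saturated chain. The true size of the step cannot be fixed, because compound 1 rests on a limit and not a number: the limit of > 300 uM in this assay, at which 1 of the 3 values shown sits.

As far as these compounds go, whether bromo or methoxy on this aromatic carbon would lower the number further remains open. So does whether chloro and the chain of compound 2 would add up in one molecule.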